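A few compounds are considered here, and "the series" means these few. Any claim that something is new, unique, unknown or untested is made for them only; others in the source may bear on it.

Compound 1 `O=C(C1CCCC1)N1CCCn2nc(COc3ccccc3)cc21` and compound 2 `O=C(c1ccccc1F)N1CCCn2nc(COc3ccccc3)cc21` share one core and differ only in the group on the carbonyl carbon. In a functional assay on HEK293 cells for positive allosteric modulation of metabotropic glutamate receptor 5 (Homo sapiens), read by calcium flux (on this read-out higher numbers stand for larger maximal responses and lower numbers for smaller maximal responses), compound 1 reaches 41%, and in this assay compound 2 reaches 62%; the change is a number 21 percentage points higher from compound 1 to compound 2 (beyond the scatter). Among the two measured numbers compound 2 thus stands highest, with compound 1 as its only neighbour, lower by that step. Compound 3 `O=C(c1ccccn1)N1CCCn2nc(COc3ccccc3)cc21` has not yet been measured. It differs from compound 2 in one place: pyridin-2-yl in place of 2-fluorophenyl on a carbonyl carbon. Going by the values given here, the only measured step that bears on this change is a number 21 percentage points higher from compound 1 to compound 2 (beyond the scatter), which also altered the group on the carbonyl carbon, but it exchanged cyclopentyl for 2-fluorophenyl, whereas here one six-membered aromatic ring replaces another. Among the compounds with values here, no measured pair shows what a ring nitrogen at this place does, so the expected change in this assay is small, within or close to the scatter, in either direction. The estimate for compound 3 in this assay is 55%, with a range from 35% to 75%, which corresponds to an expected step of a number 7 percentage points lower from compound 2 to compound 3 (within the scatter).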

Compound 3, largest response reached (reported as percent of maximum), in percent of the reference or control that the assay uses: 44%
The estimate for compound 3 lay 11 percentage points above the measured number, and the stated range covers the measured number.
By their numbers in this assay, from the lowest: compounds 1 and 3 (each within the scatter of the next); then compound 2.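

Swapping one six-membered aromatic ring for another on the carbonyl carbon is not a neutral exchange: in this assay, replacing 2-fluorophenyl with pyridin-2-yl gives a number 18 percentage points lower from compound 2 to compound 3 (beyond the scatter). Having an aromatic ring at this place is therefore not enough on its own to give the larger response, since the pyridin-2-yl group, when set against cyclopentyl, gives only a number 3 percentage points higher from compound 1 to compound 3 (within the scatter), whereas 2-fluorophenyl gave a number 21 percentage points higher from compound 1 to compound 2 (beyond the scatter). What matters here is which aromatic ring is present, but no measurement at hand explains the difference between these two rings.

Because the two rings differ both in the fluorine and in the ring nitrogen, these compounds cannot show which of the two changes accounts for the step, and a plain phenyl group on the carbonyl carbon would be the direct test of that question. From the compounds shown here alone, it also remains open how other groups at this place would behave in this assay, such as a thienyl ring, a methoxyphenyl group or a simple amine.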